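This account rests on a few compounds, and the source may have more. Where it says the series, first, only, none or still open, it means among the compounds named here.

Measured compounds in an assay on C3H 10T1/2 cells for inhibition of Sonic hedgehog protein (Mus musculus), read by a luciferase reporter; a higher number here means a weaker inhibitor, a lower number a stronger inhibitor:
- compound 1 `Cc1nc(C(F)(F)F)ccc1C(=O)Nc1ccc(Cl)c(-c2cc3ccccc3[nH]2)c1`: 500 nM
- compound 2 `Cc1nc(C(F)(F)F)ccc1C(=O)Nc1ccc(Cl)c(-n2cc3ccccc3n2)c1`: 80 nM
- compound 3 `Cc1nc(C(F)(F)F)ccc1C(=O)Nc1ccc(Cl)c(-c2cn3ccsc3n2)c1`: 200 nM

Among these three, compound 3 gives the second highest number in this assay: compound 1 gives 500 nM, a step of a 2.5-fold lower number from compound 1 to compound 3 (0.40 log units; beyond the scatter), while compound 2 gives 80 nM, a step of a 2.5-fold higher number from compound 2 to compound 3 (0.40 log units; beyond the scatter). All three share the same core and differ only in the group that sits on an aromatic carbon of a six-membered aromatic ring of carbon only, ortho to a chloro group and meta to a large group.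

Compound 4 `Cc1nc(C(F)(F)F)ccc1C(=O)Nc1ccc(Cl)c(-c2cnccn2)c1` changes that same group: a group of 6 heavy atoms (4 carbon, 2 nitrogen; one six-membered aromatic ring with 2 hetero atoms) in place of a group of 8 heavy atoms (5 carbon, 2 nitrogen, 1 sulfur; 2 five-membered aromatic rings with 2 hetero atoms each), on an aromatic carbon. The pyrazin-2-yl carries no hydrogen-bond donor and two hydrogen-bond acceptors in a single ring.

The measured steps all swap one two-ring group for another: a 6.3-fold lower number from compound 1 to compound 2 (0.80 log units; beyond the scatter), a 2.5-fold lower number from compound 1 to compound 3 (0.40 log units; beyond the scatter) and a 2.5-fold higher number from compound 2 to compound 3 (0.40 log units; beyond the scatter). None replaces a two-ring group with a single six-membered ring, so they set only the spread seen so far in this assay. Within that spread, a small shift upward from compound 3 is the expectation, a 1.5-fold higher number from compound 3 to compound 4 (0.18 log units; within the scatter), and compound 4 is estimated at 300 nM, in a range from 100 nM to 1200 nM.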

Compound 4, half-maximal inhibitory concentration: 1700 nM
Beside the measured number, compound 4's estimate is 5.7-fold (0.75 log units) below it, outside the stated range (above it).
By their numbers in this assay, from the lowest: compound 2; then compound 3; then compound 1; then compound 4.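

In this assay, among these compounds, this is the first time a two-ring group at this position, on an aromatic carbon ortho to a chloro group, gives way to a single six-membered ring, and pyrazin-2-yl gives the highest number of the four compounds (an 8.5-fold higher number from compound 3 to compound 4 (0.93 log units; beyond the scatter)) (a 21-fold higher number from compound 2 to compound 4 (1.33 log units; beyond the scatter)) (a 3.4-fold higher number from compound 1 to compound 4 (0.53 log units; beyond the scatter)). Even 1H-indol-2-yl, the two-ring group with the highest number so far, gives a lower number than pyrazin-2-yl, so all three two-ring groups shown outperform this single ring. Nothing shown gives a reason for this rise.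

Among the compounds shown here, with only one single-ring group here, the compounds leave open whether the rise goes with the loss of the second ring or with the two ring nitrogens of pyrazin-2-yl. From the compounds shown here alone, how a phenyl or a pyridin-2-yl group at this place would compare also remains open.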